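This account rests on a few compounds, and the source may have more. Where it says the series, first, only, none or still open, it means among the compounds named here.

Notes on the series. Compound 1 `Cc1ccccc1C(=O)c1ccn(-c2ccc3c(c2)B(O)OC3)c1` and compound 2 `COc1ccccc1C(=O)c1ccn(-c2ccc3c(c2)B(O)OC3)c1` share the same core and differ only by methoxy in place of methyl on an aromatic carbon. In an ADME assay on L929 cells (Mus musculus) for cytotoxicity, read by resazurin assay, with a stated time of 72 h (a higher number here means a weaker inhibitor, a lower number a stronger inhibitor), compound 1 gives no number, only a limit, > 10 ug/mL. In this assay compound 2 likewise gives only a limit, > 10 ug/mL. The step that the two limits leave unreadable from compound 1 to compound 2 therefore cannot be read, and compound 2 stands not at a number but at the limit of > 10 ug/mL in this assay, at which 2 of the 2 values shown sit. The next change, (4-aminophenyl in place of 2-methoxyphenyl on a carbonyl carbon), gives compound 3 `Nc1ccc(C(=O)c2ccn(-c3ccc4c(c3)B(O)OC4)c2)cc1`. For the measured compounds named here, no measured step bears on a change of this kind: the only step in the set, from compound 1 to compound 2, is unreadable between its two limits and so sets neither size nor direction for this assay. The expected step that the limit leaves unreadable from compound 2 to compound 3 is accordingly put at none beyond the scatter. Compound 3 is expected to give about 15 ug/mL in this assay, with a range from 7 ug/mL to 40 ug/mL, and most probably the same limit again rather than a number.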

Compound 3, half-maximal inhibitory concentration: 3.9 ug/mL
Compound 3: the middle estimate sits 3.8-fold (0.59 log units) above what was measured; measured number outside the range, below it.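

At the carbonyl carbon, this is the one change among those shown that yields a readable step in this assay: 4-aminophenyl in place of 2-methoxyphenyl gives an at least 2.5-fold lower number from compound 2 to compound 3 (0.40 log units; beyond the scatter), and 4-aminophenyl in place of 2-methylphenyl gives an at least 2.5-fold lower number from compound 1 to compound 3 (0.40 log units; beyond the scatter). Both steps run in the same direction, so the aromatic group on this carbonyl carbon can shift the read-out beyond the scatter, which the exchange of methyl for methoxy could not show, since that pair yields no readable step. Both steps give only a minimum size and not a measured one, because the two compounds they start from stand at a limit of the assay: the limit of > 10 ug/mL in this assay, at which 2 of the 3 values shown sit.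

The change replaces the substituent and its numbered place on the phenyl ring together, so the compounds shown do not separate the effect of the amine from that of its place. They also leave open how a carboxylic acid or an acetamide would read in this assay in place of the amine of the 4-aminophenyl group.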